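The source may report more compounds than this note shows. Statements on the series, on what has been measured and on what is new or still open speak of the compounds shown alone.

Compound 1 `Nc1cc(N)c2nc(-c3ccccc3)c(Sc3ccc(F)cc3)nc2c1`: < 100000 nM
Compound 2 `COc1ccc(CNc2nc3cc(N)cc(N)c3nc2-c2ccccc2)cc1OC`: < 100000 nM
Compound 3 `CCOC(=O)[C@H](CCC(=O)O)NC(=O)c1ccc(CNc2nc3cc(N)cc(N)c3nc2-c2ccccc2)cc1`: 34700 nM

The three compounds were tested in a functional assay on MOLT-4 cells (Homo sapiens) for inhibition, read by sulforhodamine B assay, with a stated time of 48 h; a higher number here means that more compound is tolerated, a lower number that less compound is tolerated. Compound 1 gives < 100000 nM there, and this is a limit of the assay rather than a number. Compound 2 also sits at a limit. Compound 3 is the only one of the three with a measured number, 34700 nM. So compound 1 stands at the limit shared by most of the set, (the limit of < 100000 nM in this assay, at which 2 of the 3 values shown sit), and no finished value places it above or below its neighbours.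

Compound 4 `COc1ccc(Sc2nc3cc(N)cc(N)c3nc2-c2ccccc2)cc1` has not yet been measured. It differs from compound 1 in one place: methoxy in place of fluoro on an aromatic carbon. Among the measured compounds shown here, no pair of measured compounds shows what such a change does here, so the expected step that the limit leaves unreadable from compound 1 to compound 4 is small, in no clear direction, and is unlikely to reach beyond the usual scatter. On that basis, compound 4 is expected to give about 50000 nM, somewhere between 15000 nM and 100000 nM.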

Compound 4, concentration lethal to 50% of the cells: < 100000 nM
Compound 4 ended at the assay's limit; the forecaster's own chance of this, stated with the estimate: 50%; the middle value lies beyond the limit too.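

Compound 1 and compound 4 both end at a limit rather than at a number, so no step between them can be read: the limit of < 100000 nM in this assay, at which 3 of the 4 values shown sit.

The compounds shown leave open whether methoxy in place of fluoro on an aromatic carbon changes how much compound the cells tolerate, and by how much.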